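The source may report more compounds than this note shows. Statements on the series, on what has been measured and on what is new or still open speak of the compounds shown alone.

Measured in a functional assay on a cell-free system (plasma, Homo sapiens) for inhibition, with Plasma (Rattus norvegicus) as the target; a higher number here means a weaker inhibitor, a lower number a stronger inhibitor:

compound 1 `O=c1cc(N2CCNCC2)oc2ccccc12`: 240000 nM
compound 2 `O=c1cc(N2CCNCC2)c2c(OCc3ccccc3)cccc2o1`: 429000 nM
compound 3 `Cc1c(OCc2ccccc2)ccc2c(N3CCNCC3)cc(=O)oc12`: 1100 nM

Compound 3 holds the lowest number of the three. Compound 1 sits at a far higher number and compound 2 higher still; both gaps lie well beyond the scatter, so compound 3 is the strongest inhibitor among the measured compounds.

Compound 4 `Cc1c(OCC2CCCN(C)C2)ccc2c(N3CCNCC3)cc(=O)oc12` has not yet been measured. It differs from compound 3 in one place: 1-methylpiperidin-3-yl in place of phenyl on a saturated chain carbon bound to an oxygen on an aromatic ring. Among the measured compounds shown here, no measured pair shows this change, so its size cannot be read from the series; the only anchor is compound 3 itself. Compounds 2 and 3 both carry the benzyloxy group and still lie far apart, which says nothing about swapping phenyl for 1-methylpiperidin-3-yl. The expectation for the step from compound 3 to compound 4 is a modest rise in the number, a 2.3-fold higher number from compound 3 to compound 4 (0.36 log units; beyond the scatter), close to the edge of the scatter. Compound 4 is therefore estimated at 2500 nM, within a range of 700 nM to 12000 nM.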

Compound 4, half-maximal inhibitory concentration: 16400 nM
Compound 4: middle estimate off by 6.6-fold (0.82 log units), on the low side, outside the stated range (above it).
By their numbers in this assay, from the lowest: compound 3; then compound 4; then compounds 1 and 2 (each within the scatter of the next).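

In this assay, 1-methylpiperidin-3-yl in place of phenyl on a saturated chain carbon bound to an oxygen on an aromatic ring gives a 15-fold higher number from compound 3 to compound 4 (1.17 log units; beyond the scatter), a large loss of inhibition. Among the compounds shown here, this is the first measured pair to vary this position, and it shows that the number responds strongly to the group carried there, with phenyl the better of the two groups tested. No measured evidence bears on the reason for this step.

For the compounds shown here, the single swap changes the aromatic ring, the ring nitrogen and the methyl group together, so their separate contributions remain unresolved. Cyclohexyl or piperidin-3-yl without the methyl group on the same chain would separate these changes, but neither is among the compounds shown.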